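Hydrazone head-group variation toward a furan analogue

The source may report more compounds than this note shows. Statements on the series, on what has been measured and on what is new or still open speak of the compounds shown alone.

Compound 1 `COc1ccccc1/C=N/N(Cc1ccccc1)Cc1ccccc1` reaches only the assay limit > 100000 nM in an assay on liver (Sus scrofa) for inhibition of glucose-6-phosphatase catalytic subunit 1 (Homo sapiens), using microsomes (on this read-out higher numbers stand for weaker inhibition and lower numbers for stronger inhibition), not a number. Compound 2 `Clc1cc(Cl)cc(/C=N/N(Cc2ccccc2)Cc2ccccc2)c1` likewise stops at the limit > 100000 nM in this assay. Compound 3 `C(=N/N(Cc1ccccc1)Cc1ccccc1)\c1cccs1` gives 1500 nM in this assay.

Within the data shown here, compound 3 is thus the only member of the series with a measured number; the other two values sit at the limit of > 100000 nM in this assay, at which 2 of the 3 values shown sit. Both steps into compound 3 are large: an at least 66-fold lower number from compound 1 to compound 3 (1.82 log units; beyond the scatter) and an at least 66-fold lower number from compound 2 to compound 3 (1.82 log units; beyond the scatter). The step that the two limits leave unreadable from compound 1 to compound 2 cannot be sized, since both ends are limits.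

Compound 4 `OCc1ccc(/C=N/N(Cc2ccccc2)Cc2ccccc2)o1` has not yet been measured. Its change from compound 3 is 5-(hydroxymethyl)furan-2-yl in place of thiophen-2-yl on a carbon with a double bond to nitrogen. Among the measured compounds shown here, no measured step replaces one five-membered heteroaryl head by another, so the two steps into compound 3 only show that the head group can move the read-out strongly; they do not tell which way a thiophene-to-furan swap with an added hydroxymethyl will go. The expected step in this assay is therefore a 2.0-fold higher number from compound 3 to compound 4 (0.30 log units; within the scatter), within or near the scatter, with a wide margin of doubt. Compound 4 is estimated at 3000 nM, with a range from 700 nM to 15000 nM.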

Compound 4, half-maximal inhibitory concentration: 16000 nM
For compound 4 the middle estimate is 5.3-fold (0.73 log units) below the measured one; measured number outside the range, above it.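

In this assay, the head group on the carbon with a double bond to nitrogen now gives a second measured number, and the swap to 5-(hydroxymethyl)furan-2-yl produces an 11-fold higher number from compound 3 to compound 4 (1.03 log units; beyond the scatter); a five-membered aromatic ring with 1 hetero atom therefore does not by itself keep the read-out at the thiophen-2-yl level. A measurable number is nevertheless not confined to thiophen-2-yl, as the new head still separates from the two other heads, with an at least 6.2-fold lower number from compound 2 to compound 4 (0.79 log units; beyond the scatter) and an at least 6.2-fold lower number from compound 1 to compound 4 (0.79 log units; beyond the scatter). Those last two steps are lower bounds, set by an assay limit and not by a number: the limit of > 100000 nM in this assay, at which 2 of the 4 values shown sit.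

As far as these compounds go, what a plain furan-2-yl head or a thiophen-2-yl head carrying hydroxymethyl would give remains open, so the ring swap and the added hydroxymethyl stay unseparated. Also open, from the compounds shown here alone, is whether a carboxylic acid or an amine in place of the hydroxymethyl would move the read-out, and whether the 5-(hydroxymethyl)furan-2-yl and thiophen-2-yl heads would keep their order on a changed core.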